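Trimming the ester chain of compound 3 to a propyl group

This account rests on a few compounds, and the source may have more. Where it says the series, first, only, none or still open, it means among the compounds named here.

Compound 1 `CN(CCCc1ccccc1)Cc1cn(CC(O)COC(=O)NCc2ccccc2)nn1`: 79%
Compound 2 `CN(CCCc1ccccc1)Cc1cn(CC(O)COCc2ccccc2)nn1`: 18%
Compound 3 `CCCCCCCC(=O)OCC(O)Cn1cc(CN(C)CCCc2ccccc2)nn1`: 12%

In an assay on nucleic acid for inhibition of Nucleic Acid, read by fluorescence, tested at 100 uM (on this read-out higher numbers stand for more inhibition at the one concentration tested (going by the name of the read-out) and lower numbers for less inhibition), compound 3 has the lowest of the three numbers. Its nearest neighbour is compound 2, which lies within the scatter of compound 3, while compound 1 stands far above it, as the step of a number 67 percentage points lower from compound 1 to compound 3 (beyond the scatter) and the step of a number 61 percentage points lower from compound 1 to compound 2 (beyond the scatter) show. The step of a number 6 percentage points lower from compound 2 to compound 3 (within the scatter) shows that exchanging one group for another at this oxygen hardly moved the number.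

Compound 4 `CCCCC(O)Cn1cc(CN(C)CCCc2ccccc2)nn1` differs from compound 3 in one place: propyl in place of (heptylcarbonyl)oxy on a saturated chain carbon, two bonds along the chain from an oxygen on a saturated carbon. Among the measured compounds shown here, no measured step removes this ester entirely, but the step from compound 2 to compound 3 bears most on it and was small. The expected step of no change at the digits printed from compound 3 to compound 4 (within the scatter) is therefore none beyond the scatter. Compound 4 is estimated at 12%, in the range 0% to 35%.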

Compound 4, a percentage reported as inhibition, at one concentration (the size of the read-out at that concentration, not a potency): 37%
The estimate for compound 4 lay 25 percentage points below the measured number; measured number above the stated range.
By their numbers in this assay, from the lowest: compounds 3 and 2 (each within the scatter of the next); then compound 4; then compound 1.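

The shorter propyl group moved the number where the earlier exchange at this oxygen had not: in this assay the change gives a number 25 percentage points higher from compound 3 to compound 4 (beyond the scatter) and, against the benzyloxy group, a number 19 percentage points higher from compound 2 to compound 4 (beyond the scatter) on the same chain carbon. Thus this position does respond, once the (heptylcarbonyl)oxy or benzyloxy group gives way to a plain propyl group. No evidence is available to account for this rise.

On these data alone, whether the gain follows from losing the oxygen or from the shorter group stays open. An ethyl group, a longer alkyl chain or an amine at this carbon could help separate the two.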